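The source may hold more compounds than are shown below. What is called first, only, known or untested is meant among the compounds shown, and "the series" means these compounds.

In a functional assay on MCF7 cells (Homo sapiens), read by MTT assay, with a stated time of 48 h (on this read-out higher numbers stand for weaker inhibition and lower numbers for stronger inhibition), compound 1 (`CCn1c(C(=O)NCCN(C)C)ccc1C(CC)(CC)c1ccc(OCC(O)C(C)(C)C)c(C)c1`) gives 660 nM and compound 2 (`CCN(CC)CCCNC(=O)c1ccc(C(CC)(CC)c2ccc(OCC(O)C(C)(C)C)c(C)c2)n1CC`) gives 190 nM, the lower of the two numbers. Compound 3 (`CCn1c(C(=O)N(C)CCC#N)ccc1C(CC)(CC)c1ccc(OCC(O)C(C)(C)C)c(C)c1`) differs from compound 2 on a carbonyl carbon: (2-cyanoethyl)(methyl)amino in place of (3-(diethylamino)propyl)amino on a carbonyl carbon. Among the measured compounds shown here, only one measured step bears on this change, and only in part: a 3.5-fold lower number from compound 1 to compound 2 (0.54 log units; beyond the scatter), a modest step beyond the scatter. For the measured compounds named here, compound 1 and compound 2 both keep the amide hydrogen and carry a dimethylamino or diethylamino group, whereas compound 3 has neither, so the data offer no direct precedent for this replacement. A step somewhat larger than that measured one is therefore expected in this assay, towards a higher number, with considerable uncertainty. The expected step is a 5.3-fold higher number from compound 2 to compound 3 (0.72 log units; beyond the scatter). For compound 3, the estimated value is 1000 nM, with an expected range from 250 nM to 4000 nM.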

Compound 3, half-maximal inhibitory concentration: > 50000 nM
Compound 3: a limit, no number; the forecaster's own chance of this, stated with the estimate: 10%; middle value at least 50-fold (1.69 log units) from the limit.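

In this assay compound 3 gives only a limit of the assay, not a number: the limit of > 50000 nM in this assay, at which 1 of the 3 values shown sits. Setting (2-cyanoethyl)(methyl)amino on the carbonyl carbon gives an at least 260-fold higher number from compound 2 to compound 3 (2.42 log units; beyond the scatter), and against the shorter amine chain it gives an at least 75-fold higher number from compound 1 to compound 3 (1.87 log units; beyond the scatter). Both steps are large, whereas exchanging one amine chain for the other gave only a 3.5-fold lower number from compound 1 to compound 2 (0.54 log units; beyond the scatter), so this position can move the read-out far more than that earlier modest step showed.

The change removes the amide hydrogen and the diethylamino group and brings in the nitrile all at once, and the compounds shown do not separate these. Open, on these data alone, is where a (2-cyanoethyl)amino group, which keeps the amide hydrogen, or a (3-(diethylamino)propyl)(methyl)amino group, which keeps the amine, would fall.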